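Swapping a ring amide substituent on a lipid-tailed dipeptide

The source may hold more compounds than are shown below. What is called first, only, known or untested is meant among the compounds shown, and "the series" means these compounds.

Compound 1 `CC(C)=CCC/C(C)=C/CC/C(C)=C/CSC[C@H](NC(=O)CCCCCN1CCN(C)CC1)C(=O)NC1CC1` gives 6300 nM in a functional assay on BXPC-3 cells (Homo sapiens) for cytotoxicity, read by fluorescence, with a stated time of 48 h; on this read-out lower numbers stand for an effect already at smaller amounts and higher numbers for an effect only at larger amounts of compound.
Compound 2 `CC(C)=CCC/C(C)=C/CC/C(C)=C/CSC[C@H](NC(=O)CCCCCN1CCN(C)CC1)C(=O)NC1CCCCCCC1` gives 7500 nM in this assay.
Compound 3 `CC(C)=CCC/C(C)=C/CC/C(C)=C/CSC[C@H](NC(=O)CCCCCN1CCCC1)C(=O)NC1CCCCCCC1` gives 4000 nM in this assay.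

Compound 4 `CC(C)=CCC/C(C)=C/CC/C(C)=C/CSC[C@H](NC(=O)CCCCCN1CCCC1)C(=O)NC1CC1` has not been measured. It differs from compound 3 by cyclopropyl in place of cyclooctyl on an amide-type nitrogen. The same change has already been made once, from compound 2 to compound 1, where it reads (cyclopropyl in place of cyclooctyl on an amide-type nitrogen); there it gave a 1.2-fold lower number from compound 2 to compound 1 (0.08 log units; within the scatter). The two cores differ by pyrrolidin-1-yl in place of 4-methylpiperazin-1-yl on a saturated chain carbon, five bonds along the chain from a carbonyl carbon, a step that gave a 1.9-fold lower number from compound 2 to compound 3 (0.27 log units; within the scatter). Because the earlier change produced a 1.2-fold lower number from compound 2 to compound 1 (0.08 log units; within the scatter), the step from compound 3 to compound 4 is expected to be similar, near a 1.1-fold lower number from compound 3 to compound 4 (0.06 log units; within the scatter). Among the compounds with values here, for compound 4 the estimated value in this assay is 3500 nM, with a plausible range from 1500 nM to 8000 nM; with only one prior example of this change, that range stays wide.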

Compound 4, half-maximal effective concentration: > 20000 nM
Compound 4 ended at the assay's limit; the forecaster's own chance of this, stated with the estimate: 5%; at least 5.7-fold (0.75 log units) between middle value and limit.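

In this assay compound 4 gives > 20000 nM as a limit of the assay, not a number. Cyclopropyl in place of cyclooctyl on the amide-type nitrogen gives an at least 5.0-fold higher number from compound 3 to compound 4 (0.69 log units; beyond the scatter), so this change did not carry over from one core to the other: the same change on two cores in this assay, a 1.2-fold lower number (0.08 log units; within the scatter) from compound 2 to compound 1 and an at least 5.0-fold higher number (0.69 log units; beyond the scatter) from compound 3 to compound 4, at least 5.9-fold (0.77 log units) apart, beyond the scatter of two such steps. Pyrrolidin-1-yl in place of 4-methylpiperazin-1-yl gives an at least 3.1-fold higher number from compound 1 to compound 4 (0.50 log units; beyond the scatter), so the outcome of each change depends on the other group present, though these four compounds do not show why or whether this holds on any further core: the same change on two cores in this assay, a 1.9-fold lower number (0.27 log units; within the scatter) from compound 2 to compound 3 and an at least 3.1-fold higher number (0.50 log units; beyond the scatter) from compound 1 to compound 4, at least 5.9-fold (0.77 log units) apart, beyond the scatter of two such steps.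

Open, from the compounds shown here alone, is whether a cyclopentyl or cyclohexyl group on the amide-type nitrogen of the core of compound 3 would read like compound 3 or like compound 4. Also open, going by these compounds, is whether a piperidin-1-yl group in place of pyrrolidin-1-yl would show the same dependence.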